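The source may hold more compounds than are shown below. What is called first, only, known or untested is meant among the compounds shown, and "the series" means these compounds.

Three compounds sharing one core were examined in a functional assay on HepG2 cells (Homo sapiens) for inhibition, read by MTT assay, with a stated time of 120 h; on this read-out higher numbers stand for weaker inhibition and lower numbers for stronger inhibition. Compound 1 `C/C(=C\c1ccc(NC(=O)Nc2ccc(Cl)c(C(F)(F)F)c2)cc1)C(=O)N1CC(C)OC(C)C1` gives only a limit of the assay, > 50000 nM. Compound 2 `CNC(=O)/C=C(\C)c1ccc(NC(=O)Nc2ccc(Cl)c(C(F)(F)F)c2)cc1` likewise gives only a limit, > 50000 nM. Compound 3 `O=C(CCc1ccc(NC(=O)Nc2ccc(Cl)c(C(F)(F)F)c2)cc1)NC1CCC1` also gives no number but a limit, > 50000 nM. For the measured compounds named here, compound 3 therefore stands where every measured compound stands: at the limit, and the single measured step, a step that the two limits leave unreadable from compound 2 to compound 3, is left unreadable because both of its ends sit at that limit. Going by the values given here, the one piece of evidence on the whole set is the limit of > 50000 nM in this assay, at which 3 of the 3 values shown sit, which says nothing about direction or size.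

Compound 4 `CNC(=O)/C=C/c1ccc(NC(=O)Nc2ccc(Cl)c(C(F)(F)F)c2)cc1` differs from compound 3 by 2-(methylcarbamoyl)ethenyl in place of 2-(cyclobutylcarbamoyl)ethyl on an aromatic carbon. Among the compounds with values here, the only step that bears on this position is the one from compound 2 to compound 3, and it is unreadable, so no measured step tells which way the change should move the read-out or by how much. With all three neighbours at the limit, compound 4 is expected to give the same picture, and the expected step of a number no higher from compound 3 to compound 4 (the limit leaves the size open) is none beyond the scatter. Compound 4 is estimated at 50000 nM, with a range from 20000 nM to 100000 nM, most likely reported again only as a limit.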

Compound 4, half-maximal inhibitory concentration: 20400 nM
Beside the measured number, compound 4's estimate is 2.5-fold (0.39 log units) above it, within the range that was stated.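

Compound 4 is the only compound here that gives a number rather than a limit in this assay, so the group on the aromatic carbon para to a large group is now shown to affect the read-out. Putting 2-(methylcarbamoyl)ethenyl in place of 2-(cyclobutylcarbamoyl)ethyl gives an at least 2.4-fold lower number from compound 3 to compound 4 (0.38 log units; beyond the scatter), and putting it in place of 1-methyl-2-(methylcarbamoyl)ethenyl gives an at least 2.4-fold lower number from compound 2 to compound 4 (0.38 log units; beyond the scatter). The full size of both steps stays open, and the remaining step cannot be read: the limit of > 50000 nM in this assay, at which 3 of the 4 values shown sit.

The compounds shown leave open whether the double bond or the methyl in place of the cyclobutyl accounts for the first of these steps, as the two changes arrive together in compound 4. They also leave open whether the saturated 2-(methylcarbamoyl)ethyl chain, a carboxylic acid or an amine at this place would give a number on this read-out, and in which direction it would lie from that of compound 4.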